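The compounds below may be only part of what the source reports. "The series", "measured", "known", "first", "only" and "open" are said of these compounds alone.

Of the compounds shown here, two sharing one core have been tested in an ADME assay on Vero cells (Chlorocebus sabaeus) for cytotoxicity, read by resazurin assay, with a stated time of 3 days; a higher number here means a weaker inhibitor, a lower number a stronger inhibitor. Compound 1 is `O=C(Nc1cc2nc(C3CCCCC3)[nH]c2cc1N1CCCC1)c1ccc(Br)cc1`. In this assay compound 1 gives only a limit, > 100 ug/mL. Compound 2 is `CCN(CC)c1cc2[nH]c(C3CCCCC3)nc2cc1NC(=O)c1ccc(OC(F)(F)F)cc1`. In this assay compound 2 likewise gives only a limit, > 100 ug/mL. Among the compounds with values here, compound 2 therefore stands where compound 1 stands, at the limit of > 100 ug/mL in this assay, at which 2 of the 2 values shown sit, and no number for either compound is available, so no measured step between them can be drawn.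

Compound 3 is `CCN(CC)c1cc2[nH]c(C3CCCCC3)nc2cc1NC(=O)c1ccc(Br)cc1`. It differs from compound 2 by bromo in place of trifluoromethoxy on an aromatic carbon. Compound 1 already carries the bromo group and also sits at that limit. The expected change is a step that the limit leaves unreadable from compound 2 to compound 3, that is, no shift beyond the usual scatter. For compound 3 the estimate in this assay is 120 ug/mL, with a range from 50 ug/mL to 300 ug/mL, and the result is expected to be reported once more as a limit rather than a number.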

Compound 3, half-maximal inhibitory concentration: > 100 ug/mL
Compound 3: no number, only a limit (the forecaster's own chance of this, stated with the estimate: 80%); the middle value lies beyond the limit too.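

Compound 1, compound 2 and compound 3 all give only limits in this assay, so no step among them can be read: the limit of > 100 ug/mL in this assay, at which 3 of the 3 values shown sit.

The compounds shown leave open whether exchanging trifluoromethoxy for bromo, or pyrrolidin-1-yl for diethylamino, changes the half-maximal inhibitory concentration at all.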